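Swapping Benzyl for Hydroxycyclohexyl at the Aryl Ether

The compounds below may be only part of what the source reports. "The series", "measured", "known", "first", "only" and "open" are said of these compounds alone.

Measured in a functional assay on HeLa cells (Homo sapiens) for inhibition, read by CCK-8 assay, with a stated time of 48 h; a lower number here means a stronger inhibitor, a higher number a weaker inhibitor:
compound 1 `CC(C)c1ccc(Oc2ccc(O)c(O)c2)c(-c2ccsc2S(=O)(=O)NCCNC(=S)Nc2ccc([N+](=O)[O-])cc2)c1` gives > 20000 nM
compound 2 `O=C(NCCNS(=O)(=O)c1ccc(-c2ccccc2Oc2ccc([N+](=O)[O-])c([N+](=O)[O-])c2)s1)Nc1cc(C(F)(F)F)cc(C(F)(F)F)c1` gives > 50000 nM
compound 3 `O=C(NCCNS(=O)(=O)c1ccc(-c2ccccc2OCc2ccccc2)s1)Nc1cc(C(F)(F)F)cc(C(F)(F)F)c1` gives 13500 nM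

The value of compound 1 is a limit of the assay, not a number. The value of compound 2 is likewise a limit. Compound 3 thus stands with the only number shown. For the measured compounds named here, the one measured step, an at least 3.7-fold lower number from compound 2 to compound 3 (0.56 log units; beyond the scatter), changes the same oxygen on an aromatic ring that is changed here. Compound 4 `O=C(NCCNS(=O)(=O)c1ccc(-c2ccccc2O[C@H]2CC[C@H](O)CC2)s1)Nc1cc(C(F)(F)F)cc(C(F)(F)F)c1` carries 4-hydroxycyclohexyl in place of benzyl on an oxygen on an aromatic ring. Going by the values given here, no measured step tests this particular exchange, so the expectation rests loosely on compound 3 alone: a step of a 1.1-fold higher number from compound 3 to compound 4 (0.05 log units; within the scatter) is expected, with a fair chance that only a limit is reported. Compound 4 is therefore estimated at 15000 nM, within 5000 nM to 50000 nM.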

Compound 4, half-maximal inhibitory concentration: > 20000 nM
Compound 4 gave a limit, no number; the forecaster's own chance of this, stated with the estimate: 30%; middle value at least 1.3-fold (0.12 log units) away from the limit.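

The value of compound 4 is a limit, not a number: the limit of > 20000 nM in this assay, at which 2 of the 4 values shown sit.

Against benzyl on this oxygen, 4-hydroxycyclohexyl gives an at least 1.4-fold higher number from compound 3 to compound 4 (0.17 log units; that floor lies within the scatter), so this exchange yields no stronger inhibitor than compound 3, yet a true loss is not shown either. The step from compound 2 to compound 4 cannot be read, as both values are limits.

Still open, going by these compounds, is whether an amine or a carboxylic acid on this oxygen's substituent, or a longer chain ending in a phenyl ring, would give a lower number than compound 3.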